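The source may report more compounds than this note shows. Statements on the series, on what has been measured and on what is new or still open speak of the compounds shown alone.

Of the compounds shown here, two built on the same core have so far been tested in a functional assay on cells (Cancer cell lines, Homo sapiens) for cytotoxicity; a lower number here means a stronger inhibitor of growth, a higher number a weaker inhibitor of growth. Compound 1 `O=C(/C=C/C(=O)N1C/C(=C\c2ccccc2)C(=O)/C(=C/c2ccccc2)C1)Nc1ccc(Cl)c(Cl)c1` carries a 3,4-dichlorophenyl group on its amide nitrogen, and in this assay compound 1 gives 646 nM. Compound 2 `COc1ccc(NC(=O)/C=C/C(=O)N2C/C(=C\c3ccccc3)C(=O)/C(=C/c3ccccc3)C2)cc1` carries a 4-methoxyphenyl group in the same place, and in this assay compound 2 gives 759 nM. Among these two numbers compound 2 stands alongside compound 1: the step of a 1.2-fold higher number from compound 1 to compound 2 (0.07 log units; within the scatter) is within the scatter, so the two values cannot be told apart.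

Compound 3 `O=C(/C=C/C(=O)N1C/C(=C\c2ccccc2)C(=O)/C(=C/c2ccccc2)C1)Nc1ccc(Cl)cc1` is the next compound, not yet measured. It differs from compound 2 in one spot: chloro in place of methoxy on an aromatic carbon. Within the data shown here, the only measured step that bears on this swap is a 1.2-fold higher number from compound 1 to compound 2 (0.07 log units; within the scatter), which exchanged one chloro-bearing ring for the methoxy-bearing ring and moved nothing beyond the scatter. With so small a precedent, no step beyond the scatter is expected in this assay in either direction, and the estimated step of a 1.1-fold lower number from compound 2 to compound 3 (0.04 log units; within the scatter) reflects that. Compound 3 is therefore expected to give about 700 nM, with a likely range from 350 nM to 1400 nM.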

Compound 3, concentration for 50% growth inhibition: 1150 nM
Beside the measured number, compound 3's estimate is 1.6-fold (0.22 log units) below it; measured number inside the range.
By their numbers in this assay, from the lowest: compounds 1, 2 and 3 (each within the scatter of the next).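

In this assay, the exchange of methoxy for chloro on the aromatic carbon para to a large group gives a 1.5-fold higher number from compound 2 to compound 3 (0.18 log units; within the scatter) and so leaves the number unresolved from that of the methoxy compound, even though the two groups differ in their atoms and in the hydrogen-bond acceptor that methoxy carries. The earlier pair changed two ring positions at once, whereas the step with hydrogen in place of chloro, a 1.8-fold higher number from compound 1 to compound 3 (0.25 log units; within the scatter) and likewise within the scatter, isolates a single chloro and shows no readable effect from it on this ring. Nothing measured here explains these small steps, and no outside observation bears on them.

What the compounds shown leave open is whether any group on this carbon can move the number beyond the scatter, for instance an amine, a carboxylic acid or a longer chain such as butoxy. They also leave open whether changes elsewhere on the shared core, rather than on this aromatic ring, would shift growth inhibition more strongly.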